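This account rests on a few compounds, and the source may have more. Where it says the series, first, only, none or still open, it means among the compounds named here.

Of the compounds shown here, two have so far been tested in a functional assay on HeLa cells (Homo sapiens) for cytotoxicity, read by XTT assay, with a stated time of 72 h; on this read-out higher numbers stand for weaker inhibition and lower numbers for stronger inhibition. Compound 1 `CCn1ccc2cc(/C(=N/OC(C)=O)c3cc(OC)c(OC)c(OC)c3)ccc21` carries an acetoxy group on its double-bonded nitrogen. In this assay compound 1 reaches only the limit > 10000 nM, and no number is known for it. Compound 2 `COc1cc(/C(=N/NC(C)=O)c2ccc3c(ccn3C)c2)cc(OC)c1OC` carries an acetamido group at the same place, and in this assay compound 2 gives 2300 nM. Going by the values given here, compound 2 therefore holds the only real number in the set; the other entry is a limit (the limit of > 10000 nM in this assay, at which 1 of the 2 values shown sits), so the set contains no measured step that could be placed beside a new one.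

Compound 3 `COc1cc(/C(=N/C(=O)OC(C)(C)C)c2ccc3c(ccn3C)c2)cc(OC)c1OC` is the next member, differing from compound 2 in one place: tert-butoxycarbonyl in place of acetamido on a double-bonded nitrogen. Among the compounds with values here, with no measured step of a comparable kind to lean on, the expectation rests on compound 2 alone. The step is expected to run toward weaker inhibition, a 2.6-fold higher number from compound 2 to compound 3 (0.42 log units; beyond the scatter), with a wide margin of doubt around that size. Compound 3 is expected to give about 6000 nM in this assay, within a range from 1500 nM to 25000 nM, with a fair chance that only a limit is reported.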

Compound 3, half-maximal inhibitory concentration: > 1000 nM
Compound 3: only a limit was reported (the forecaster's own chance of this, stated with the estimate: 35%); the middle value is on the limit's open side.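

In this assay compound 3 reaches only a limit, > 1000 nM, and this is not a number, so the step from compound 2 to compound 3 cannot be read. The compounds shown leave open whether tert-butoxycarbonyl in place of acetamido on a double-bonded nitrogen strengthens or weakens inhibition, and by how much.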